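The source may hold more compounds than are shown below. What is called first, only, known or untested is meant among the compounds shown, and "the series" means these compounds.

Compound 1 `Fc1ccccc1CSc1nnc(-c2ccncc2)n1-c1ccccc1` opens the series in a functional assay on MCF7 cells (Homo sapiens) for inhibition, read by MTT assay, with a stated time of 48 h; a higher number here means a weaker inhibitor, a lower number a stronger inhibitor. In this assay compound 1 gives only a limit, > 50000 nM. Compound 2 `Brc1cccc(CSc2nnc(-c3ccncc3)n2-c2ccccc2)c1` carries 3-bromophenyl in place of 2-fluorophenyl on a saturated chain carbon bound to a sulfur, and in this assay compound 2 gives 10000 nM. Within the data shown here, the step of an at least 5.0-fold lower number from compound 1 to compound 2 (0.69 log units; beyond the scatter) is the only measured change, and it rests on (the limit of > 50000 nM in this assay, at which 1 of the 2 values shown sits), so its full size is not fixed. Among the measured compounds shown here, compound 2 therefore stands as the only compound with a number in this assay, the one further value being a limit.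

Compound 3 `O=[N+]([O-])c1cccc(CSc2nnc(-c3ccncc3)n2-c2ccccc2)c1` differs from compound 2 by nitro in place of bromo on an aromatic carbon, meta to a large group. For the measured compounds named here, no measured step touches this position or this exchange; the single step from compound 1 to compound 2 concerned a different group at a different place. The expectation for compound 3 is therefore anchored on compound 2 alone, with an expected step of a 1.2-fold higher number from compound 2 to compound 3 (0.08 log units; within the scatter) that stays within the scatter. Compound 3 is estimated at 12000 nM in this assay, with a range from 4000 nM to 40000 nM.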

Compound 3, half-maximal inhibitory concentration: 18300 nM
Beside the measured number, compound 3's estimate is 1.5-fold (0.18 log units) below it, within the range that was stated.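

Bromo to nitro on an aromatic carbon, meta to a large group, is the first measured exchange at this place, and in this assay it gives a 1.8-fold higher number from compound 2 to compound 3 (0.26 log units; within the scatter), so 3-bromophenyl and 3-nitrophenyl are not told apart here, although nitro is the larger group and, unlike bromo, carries hydrogen-bond acceptors. The second aryl exchange reads an at least 2.7-fold lower number from compound 1 to compound 3 (0.43 log units; beyond the scatter), and its full size is not fixed: the limit of > 50000 nM in this assay, at which 1 of the 3 values shown sits. Both 3-substituted compounds thus stand on the same side of the 2-fluorophenyl compound, whichever of the two groups is present, and no compound shown goes against this within the three.

Among these compounds, open is how far this tolerance at the aromatic carbon extends, for example to an amine or a carboxylic acid in the same place, since bromo and nitro are the only two groups compared there. Also open is whether the gap to compound 1 follows the change from fluoro to another group or the different place of that group on the ring, as these two changes travel together in the compounds shown.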